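This account rests on a few compounds, and the source may have more. Where it says the series, first, only, none or still open, it means among the compounds named here.

Measured compounds in a functional assay on HeLa cells (Homo sapiens) for inhibition, read by CCK-8 assay, with a stated time of 48 h; a lower number here means a stronger inhibitor, a higher number a weaker inhibitor:

Compound 1, `COc1ccc(NC(=O)NCCNS(=O)(=O)c2ccc(-c3ccccc3Oc3ccc([N+](=O)[O-])cc3)s2)cc1`, gives only the assay limit > 20000 nM.
Compound 2, `O=S(=O)(c1sccc1-c1ccccc1Oc1ccc(O)c(O)c1)N1CCN(C(=S)Nc2cc(C(F)(F)F)cc(C(F)(F)F)c2)CC1`, gives only the assay limit > 20000 nM.
Compound 3, `COc1ccc(NC(=O)NCCNS(=O)(=O)c2ccc(-c3ccccc3Oc3ccc([N+](=O)[O-])c([N+](=O)[O-])c3)s2)cc1`, gives only the assay limit > 20000 nM.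

Compound 3 differs from compound 1 by nitro in place of hydrogen on an aromatic carbon. The step that the two limits leave unreadable from compound 1 to compound 3 cannot be read in size, since both ends of it sit at the limit of > 20000 nM in this assay, at which 3 of the 3 values shown sit.

Compound 4, `O=[N+]([O-])c1ccc(Oc2ccc(O)c(O)c2)c(-c2ccsc2S(=O)(=O)N2CCN(C(=S)Nc3cc(C(F)(F)F)cc(C(F)(F)F)c3)CC2)c1`, is not yet measured in this assay and differs from compound 2 by nitro in place of hydrogen on an aromatic carbon. This is the same kind of change as that from compound 1 to compound 3, not the same one: in compound 3 the entering nitro sits ortho to a nitro group and meta to a large group, whereas in compound 4 it sits meta to a large group and para to a 3,4-dihydroxyphenoxy group. The difference between the cores of compound 1 and compound 2 is not broken down here.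

For compound 4 the step that the limit leaves unreadable from compound 2 to compound 4 is expected, resting on compound 2 with its limit > 20000 nM and on the measured pair in which every value sits at the limit of > 20000 nM in this assay, at which 3 of the 3 values shown sit. Compound 4 is therefore estimated at 30000 nM, most likely again reported only as a limit.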

Compound 4, half-maximal inhibitory concentration: > 20000 nM
Compound 4: a limit, no number (the forecaster's own chance of this, stated with the estimate: 80%); the middle value is on the limit's open side.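

Compound 2 and compound 4 both give only a limit and not a number, so no new step can be read from this pair: the limit of > 20000 nM in this assay, at which 4 of the 4 values shown sit. The compounds shown leave open how strongly any of them acts in this assay, and whether nitro in place of hydrogen on an aromatic carbon changes that at all.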